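Swapping the amide ring in a series measured for platelet-activating factor acetylhydrolase inhibition

The source may hold more compounds than are shown below. What is called first, only, known or untested is meant among the compounds shown, and "the series" means these compounds.

Measured so far:
Compound 1, `CCCCCCCCN(C)C(=O)Cn1cc(Cc2cnc(=O)n(CC)c2)c(=O)nc1SCc1ccc(F)cc1`: 5%
Compound 2, `CCCCCCCCN(C)C(=O)Cn1cc(Cc2cnc(=O)n(CC(=O)O)c2)c(=O)nc1SCc1ccc(F)cc1`: 27%
Compound 3, `CCCCCCCCN(C)C(=O)Cn1cc(Cc2cnc(=O)n(CC(=O)N3CCOCC3)c2)c(=O)nc1SCc1ccc(F)cc1`: 36%

In a functional assay on a cell-free system (plasma, Oryctolagus cuniculus) for inhibition of platelet-activating factor acetylhydrolase (Homo sapiens), tested at 100 nM (on this read-out higher numbers stand for more inhibition at the one concentration tested (going by the name of the read-out) and lower numbers for less inhibition), compound 3 gives the highest of the three numbers, though compound 2 sits close to it and the gap between them is within the scatter, so no order between those two can be claimed. Only compound 1 lies clearly lower.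

Compound 4, `CCCCCCCCN(C)C(=O)Cn1cc(Cc2cnc(=O)n(CC(=O)N3CCN(C)CC3)c2)c(=O)nc1SCc1ccc(F)cc1`, differs from compound 3 by 4-methylpiperazin-1-yl in place of morpholin-4-yl on a carbonyl carbon. Among the measured compounds shown here, the one measured step at the same place, a number 9 percentage points higher from compound 2 to compound 3 (within the scatter), was within the scatter, so changing what sits on that carbonyl carbon has not yet shifted the read-out by a reliable amount. The larger steps, a number 22 percentage points higher from compound 1 to compound 2 (beyond the scatter) and a number 31 percentage points higher from compound 1 to compound 3 (beyond the scatter), came from installing the carbonyl-bearing chain itself, which compound 4 keeps. On this basis the estimate for compound 4 is 38%, between 20% and 58%, a step of a number 2 percentage points higher from compound 3 to compound 4 (within the scatter) expected to stay within the scatter.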

Compound 4, a percentage reported as inhibition, at one concentration (the size of the read-out at that concentration, not a potency): 40%
Compound 4: the middle estimate sits 2 percentage points below what was measured; the range from low to high includes it.
By their numbers in this assay, from the lowest: compound 1; then compounds 2, 3 and 4 (each within the scatter of the next, the first and the last beyond it).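

In this assay, 4-methylpiperazin-1-yl in place of morpholin-4-yl on the carbonyl carbon gives a number 4 percentage points higher from compound 3 to compound 4 (within the scatter), so these two ring amides cannot be told apart at this position. Measured against hydroxy on that carbon, however, 4-methylpiperazin-1-yl gives a number 13 percentage points higher from compound 2 to compound 4 (beyond the scatter), which morpholin-4-yl did not achieve with its step of a number 9 percentage points higher from compound 2 to compound 3 (within the scatter), while the whole (4-methylpiperazin-1-yl)carbonyl group in place of methyl gives a number 35 percentage points higher from compound 1 to compound 4 (beyond the scatter) on the chain. Nothing available explains these differences.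

The compounds shown leave open whether the second hetero atom of the ring matters, a question that a piperidin-1-yl amide, with carbon in that place, could answer. They also leave open whether a ring is needed at all on the carbonyl carbon, which an open-chain dimethylamino amide could test.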